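Chain change on compound 3

This account rests on a few compounds, and the source may have more. Where it says the series, first, only, none or still open, it means among the compounds named here.

Measured in a functional assay on T98G cells (Homo sapiens) for inhibition, read by colorimetric assay and MTT assay, with a stated time of 72 h; on this read-out lower numbers stand for stronger inhibition and higher numbers for weaker inhibition:
compound 1 `Cc1ccc2c(c1)-c1cnc(n1C)OCCCCCCCCO2`: 63000 nM
compound 2 `Cn1c2cnc1OCCCCCCCCOc1cc(F)ccc1-2`: 69000 nM
compound 3 `CCCCCCOc1ncc(-c2ccccc2OC)n1C`: 58000 nM

The three values lie within the usual scatter of one another, and compound 3 at 58000 nM stands level with the other two. Compound 4 `C=CCCCCOc1ncc(-c2ccccc2OC)n1C` carries vinyl in place of ethyl on a saturated chain carbon, four bonds along the chain from an oxygen on an aromatic ring. Among the compounds with values here, no measured pair shows a change of this kind, so the evidence is indirect. In this assay no step beyond the scatter is expected, and the estimated 1.1-fold lower number from compound 3 to compound 4 (0.02 log units; within the scatter) is small. For compound 4 the estimate is 55000 nM (expected range 30000 nM to 100000 nM).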

Compound 4, half-maximal inhibitory concentration: 5000 nM
The estimate for compound 4 lay 11-fold (1.04 log units) above the measured number; measured number outside the range, below it.
By their numbers in this assay, from the lowest: compound 4; then compounds 3, 1 and 2 (each within the scatter of the next).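

In this assay, within the data shown here, this chain position responds strongly to a small change: vinyl in place of ethyl gives a 12-fold lower number from compound 3 to compound 4 (1.06 log units; beyond the scatter), the only step so far. Two heavy atoms leave and two enter, so the step accompanies the one double bond outside aromatic rings, with no change in heavy-atom count. No data at hand bear on why the number moves.

Open, on these data alone, is whether an ethynyl group at this place, or a longer chain ending in vinyl, would keep the step. Also open, as far as these compounds go, is whether the step carries over to the core of compound 1.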